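Swapping a Ring Amine for Dimethylamino on the Core

The source may hold more compounds than are shown below. What is called first, only, known or untested is meant among the compounds shown, and "the series" means these compounds.

Compound 3 `CCCc1cc(N2CCC2)c2cc(NC(=O)/C=C/c3ccc(C(F)(F)F)cc3)ccc2n1` is the strongest binder among the three compounds measured: in an assay on isolated protein for displacement of a labelled ligand from melanin-concentrating hormone receptor 1 (Homo sapiens) (a lower number here means a stronger inhibitor, a higher number a weaker inhibitor), compound 3 gives 2.8 nM. Its closest neighbour is compound 2 `CCCc1cc(NC2CCC2)c2cc(NC(=O)/C=C/c3ccc(C(F)(F)F)cc3)ccc2n1`, which in this assay gives 18 nM; the step of a 6.4-fold lower number from compound 2 to compound 3 (0.81 log units; beyond the scatter) shows what closing the amine into a small ring did. Far behind stands compound 1 `CCCc1cc(N)c2cc(NC(=O)CCc3ccccc3)ccc2n1`, which in this assay gives 8300 nM.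

Compound 4 `CCCc1cc(N(C)C)c2cc(NC(=O)/C=C/c3ccc(C(F)(F)F)cc3)ccc2n1` differs from compound 3 in one place: dimethylamino in place of azetidin-1-yl on an aromatic carbon. Within the data shown here, only the step from compound 2 to compound 3 bears on this part of the shared core, and it concerned a secondary amine becoming a ring amine rather than one tertiary amine becoming another. The change to compound 4 keeps a tertiary amine of similar size, so no step beyond the scatter is expected, though the direction is uncertain. For compound 4 the expected result in this assay is 6 nM, within 2 nM to 20 nM. That expectation corresponds to the step of a 2.1-fold higher number from compound 3 to compound 4 (0.33 log units; beyond the scatter).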

Compound 4, half-maximal inhibitory concentration: 43 nM
For compound 4 the middle estimate is 7.2-fold (0.86 log units) below the measured one; the measured number lies above the stated range.
By their numbers in this assay, from the lowest: compound 3; then compound 2; then compound 4; then compound 1.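

Keeping a tertiary amine at this place on the shared core does not preserve the result: in this assay the step of a 15-fold higher number from compound 3 to compound 4 (1.19 log units; beyond the scatter) shows that opening azetidin-1-yl to dimethylamino, with one carbon fewer and no ring, is a large change even though the counts of hydrogen-bond donors and acceptors stay the same. The step of a 2.4-fold higher number from compound 2 to compound 4 (0.38 log units; beyond the scatter) also puts dimethylamino on the weaker side of cyclobutylamino, so losing the amine hydrogen does not by itself bring a low number. No measurement here explains why these groups differ.

From the compounds shown here alone, it remains open whether larger ring amines such as pyrrolidin-1-yl or piperidin-1-yl would match azetidin-1-yl. How diethylamino, a longer open-chain amine, would compare with dimethylamino is also unknown.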